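From a propyl amide to a pyridine amide

The source may hold more compounds than are shown below. What is called first, only, known or untested is meant among the compounds shown, and "the series" means these compounds.

The measured compounds in a functional assay (Sus scrofa) with sulfonylurea receptors; K-ATP channels (Homo sapiens) as the target (a lower number here means that less compound is needed, a higher number that more compound is needed for the effect), are these: compound 1 `CCCC(=O)Nc1c(C(O)(C(F)(F)F)C(F)(F)F)ccc2ccccc12` gives 708 nM; compound 2 `O=C(Nc1c(C(O)(C(F)(F)F)C(F)(F)F)ccc2ccccc12)c1cccc(Cl)c1` gives 851 nM; compound 3 `N#Cc1cccc(C(=O)Nc2c(C(O)(C(F)(F)F)C(F)(F)F)ccc3ccccc23)c1` gives 372 nM.

Compound 1 stands second highest of the three numbers. Its nearest neighbour is compound 2, reached by a 1.2-fold higher number from compound 1 to compound 2 (0.08 log units; within the scatter), and its furthest is compound 3, reached by a 1.9-fold lower number from compound 1 to compound 3 (0.28 log units; within the scatter). Between the two aryl amides there is a 2.3-fold lower number from compound 2 to compound 3 (0.36 log units; beyond the scatter).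

The unmeasured compound 4 `O=C(Nc1c(C(O)(C(F)(F)F)C(F)(F)F)ccc2ccccc12)c1cccnc1` differs from compound 1 in one place: pyridin-3-yl in place of propyl on a carbonyl carbon. The two steps that bear on it, from compound 1 to compound 2 and from compound 1 to compound 3, each replace the propyl on the carbonyl carbon by an aromatic ring and both stay within the scatter, with the ring bearing an acceptor-type substituent giving the lower number. A pyridin-3-yl brings one hydrogen-bond acceptor into the ring itself, so a small lowering, likely within the scatter, is expected. The estimated step is a 1.6-fold lower number from compound 1 to compound 4 (0.20 log units; within the scatter). Compound 4 is therefore expected to give 450 nM in this assay, with a range from 200 nM to 1000 nM.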

Compound 4, half-maximal effective concentration: 617 nM
Estimate against measurement, compound 4: 1.4-fold (0.14 log units) below; the range from low to high includes it.
By their numbers in this assay, from the lowest: compounds 3, 4, 1 and 2 (each within the scatter of the next, the first and the last beyond it).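

In this assay, replacing propyl with pyridin-3-yl on the carbonyl carbon brings a ring hetero atom and a hydrogen-bond acceptor into this position, and the result is a 1.1-fold lower number from compound 1 to compound 4 (0.06 log units; within the scatter). Compound 4 also stays within the scatter of both other aryl amides, with a 1.7-fold higher number from compound 3 to compound 4 (0.22 log units; within the scatter) and a 1.4-fold lower number from compound 2 to compound 4 (0.14 log units; within the scatter). It therefore cannot be told apart from any of the three earlier compounds, and the step between the chloro and cyano rings remains the only one beyond the scatter.

The compounds shown leave open whether a longer chain, or a ring carrying an amine or a carboxylic acid, on this carbonyl carbon would give a step beyond the scatter from compound 1. Nothing given here offers an explanation for these numbers.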